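Pyridyl isomer swap and cytotoxicity in the series

The compounds below may be only part of what the source reports. "The series", "measured", "known", "first", "only" and "open" are said of these compounds alone.

Three compounds of the series have been run in an ADME assay on 2209-23 cells (Homo sapiens) for cytotoxicity, read by WST assay; on this read-out higher numbers stand for lower toxicity in this test and lower numbers for higher toxicity in this test. Compound 1 `CS(=O)(=O)Nc1ccc2c(c1)S(=O)(=O)C=C(c1c(O)c3cc(F)ccc3n(Cc3ccc(F)cc3)c1=O)N2` gives only a limit of the assay, > 50000 nM. Compound 2 `CS(=O)(=O)Nc1ccc2c(c1)S(=O)(=O)C=C(c1c(O)c3cc(F)ccc3n(Cc3ccc(F)c(Cl)c3)c1=O)N2` likewise gives only a limit, > 50000 nM. Compound 3 `CS(=O)(=O)Nc1ccc2c(c1)S(=O)(=O)C=C(c1c(O)c3cc(F)ccc3n(Cc3cccnc3)c1=O)N2` also gives only a limit, > 50000 nM; on the numbers shown it stands at the same limit as the other two, with no number that would set it apart. All three values sit at the limit of > 50000 nM in this assay, at which 3 of the 3 values shown sit.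

The steps among these three cannot be sized: a step that the two limits leave unreadable from compound 1 to compound 2, a step that the two limits leave unreadable from compound 1 to compound 3 and a step that the two limits leave unreadable from compound 2 to compound 3 all remain unreadable, both ends of each pair being limits.

Compound 4 `CS(=O)(=O)Nc1ccc2c(c1)S(=O)(=O)C=C(c1c(O)c3cc(F)ccc3n(Cc3ccncc3)c1=O)N2` is not yet measured. It differs from compound 3 by pyridin-4-yl in place of pyridin-3-yl on a saturated chain carbon bound to an aromatic nitrogen. The measured steps that touch the same place, a step that the two limits leave unreadable from compound 1 to compound 3 and a step that the two limits leave unreadable from compound 2 to compound 3, give no readable size, so no guidance on direction is available. Given that every value so far sits at the limit in this assay, no step beyond the scatter is expected, and the expected step that the limit leaves unreadable from compound 3 to compound 4 is near zero. Compound 4 is estimated at 60000 nM, with a range from 30000 nM to 150000 nM, most probably reported again only as a limit.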

Compound 4, half-maximal cytotoxic concentration: > 50000 nM
Compound 4: a limit, no number; the forecaster's own chance of this, stated with the estimate: 85%; the middle value does not contradict the limit.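

In this assay compound 4 gives > 50000 nM, again only a limit of the assay. Its steps from compound 1, compound 2 and compound 3 therefore cannot be read: the limit of > 50000 nM in this assay, at which 4 of the 4 values shown sit.

The compounds shown leave open whether pyridin-4-yl, pyridin-3-yl, 4-fluorophenyl and 3-chloro-4-fluorophenyl differ at all on this read-out.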